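The source may hold more compounds than are shown below. What is called first, only, known or untested is meant among the compounds shown, and "the series" means these compounds.

The compounds here share one core, seen in compound 1 `COc1cccc(NC(=O)c2nnn(Cc3ccccc3)c2N)c1`, compound 2 `COc1cccc(NC(=O)c2nnn(CC3CCN(C(C)=O)CC3)c2N)c1` and compound 3 `COc1cccc(NC(=O)c2nnn(CC3CCN(C(=O)OC(C)(C)C)CC3)c2N)c1`. In a physicochemical assay for solubility, read by nephelometry, at pH 7.4 (on this read-out higher numbers stand for higher solubility and lower numbers for lower solubility), compound 1 gives 16000 nM. Compound 3 gives 39000 nM. For compound 2 the assay reports no number but only a limit, > 250000 nM. Among the values shown, compound 2 therefore stands at the top, at the limit of > 250000 nM in this assay, at which 1 of the 3 values shown sits. The two measured steps were an at least 15-fold higher number from compound 1 to compound 2 (1.19 log units; beyond the scatter) and an at least 6.4-fold lower number from compound 2 to compound 3 (0.80 log units; beyond the scatter). Compound 4 `COc1cccc(NC(=O)c2nnn(Cc3ccncc3)c2N)c1` has not yet been measured; it arises from compound 2 by pyridin-4-yl in place of 1-acetylpiperidin-4-yl on a saturated chain carbon bound to an aromatic nitrogen. The step that bears most on this change is an at least 15-fold higher number from compound 1 to compound 2 (1.19 log units; beyond the scatter), as it covers the same place and pyridin-4-yl is, like phenyl, an aromatic ring. Compound 2 is thus expected to lose solubility in this assay on the way to compound 4, in a step estimated as an at least 4.1-fold lower number from compound 2 to compound 4 (0.61 log units; beyond the scatter), smaller than that earlier step reversed. Compound 4 is expected to give 60000 nM, in a range from 20000 nM to 200000 nM.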

Compound 4, solubility: < 12000 nM
Compound 4: only a limit was reported; the forecaster's own chance of this, stated with the estimate: 15%; middle value at least 5.0-fold (0.69 log units) from the limit.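

Read in this assay, pyridin-4-yl in place of 1-acetylpiperidin-4-yl gives an at least 20-fold lower number from compound 2 to compound 4 (1.31 log units; beyond the scatter), so this one place, on a saturated chain carbon bound to an aromatic nitrogen, spans a wide range, and the lower end of that range is only a limit, not a number: the limit of < 12000 nM in this assay, at which 1 of the 4 values shown sits.

The upper end is also only a limit: the limit of > 250000 nM in this assay, at which 1 of the 4 values shown sits.

Against phenyl, the ring nitrogen of pyridin-4-yl brings no rise, since the step is an at least 1.3-fold lower number from compound 1 to compound 4 (0.12 log units; that floor lies within the scatter), so these two aromatic rings cannot be firmly ordered.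

Going by these compounds, with limits at both ends, the true size of the large step stays open. Also open, on these data alone, is how a free piperidine amine or a carboxylic acid at this place would read, compared with the acetyl-capped ring of compound 2.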